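Trifluoromethoxy for Hydroxy on a Cytotoxicity Read-out

The source may report more compounds than this note shows. Statements on the series, on what has been measured and on what is new or still open speak of the compounds shown alone.

Compound 1 `CCOC(=O)CCCCCOc1cccc(CN(C(=O)c2ccc(-c3cccnc3)cc2)C(C)C)c1`: > 26000 nM, a limit of the assay
Compound 2 `CCOC(=O)CCCCCOc1cccc(CN(C(=O)c2ccc(-c3cccc(O)c3)cc2)C(C)C)c1`: > 26000 nM, a limit of the assay

In an ADME assay on Raji cells (Homo sapiens) for cytotoxicity, read by CellTiter-Glo and resazurin assay, with a stated time of 72 h (on this read-out higher numbers stand for an effect only at larger amounts of compound and lower numbers for an effect already at smaller amounts), compound 2 gives only a limit, > 26000 nM. Compound 1 also stands at a limit there. Both values sit at the limit of > 26000 nM in this assay, at which 2 of the 2 values shown sit, so the step that the two limits leave unreadable from compound 1 to compound 2 cannot be read. Compound 3 `CCOC(=O)CCCCCOc1cccc(CN(C(=O)c2ccc(-c3cccc(OC(F)(F)F)c3)cc2)C(C)C)c1` carries trifluoromethyl in place of hydrogen on an oxygen on an aromatic ring. Among the measured compounds shown here, no measured step gives a readable size for such a change, so no shift beyond the scatter is expected, and the step of a number no higher from compound 2 to compound 3 (the limit leaves the size open) is an estimate only. Compound 3 is expected at 26000 nM, within 12000 nM to 60000 nM, most likely again reported as a limit.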

Compound 3, half-maximal effective concentration: > 26000 nM
Compound 3 gave a limit, no number (the forecaster's own chance of this, stated with the estimate: 85%); the middle value sits exactly at the limit.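

Among the compounds shown here, compound 1, compound 2 and compound 3 each give only a limit of the assay, so no step among them can be read. The compounds shown leave open whether pyridin-3-yl, 3-hydroxyphenyl or 3-(trifluoromethoxy)phenyl shifts the read-out at all.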